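From a Methyl to an Ethyl on the Phenyl Ester

A few compounds are considered here, and "the series" means these few. Any claim that something is new, unique, unknown or untested is made for them only; others in the source may bear on it.

Measured compounds:
- compound 1, `CCc1ccccc1OS(=O)(=O)c1cccc(NC(=O)NCCCCl)c1`: 24000 nM
- compound 2, `CCNC(=O)Nc1cccc(S(=O)(=O)Oc2ccccc2C)c1`: 51000 nM

In a functional assay on M21 cells (Homo sapiens) for cytotoxicity, read by sulforhodamine B assay, with a stated time of 48 h (a higher number here means a weaker inhibitor, a lower number a stronger inhibitor), compound 1 gives 24000 nM. Compound 2 gives 51000 nM, the higher of the two numbers, and the gap between them lies beyond the scatter. Compound 3, `CCNC(=O)Nc1cccc(S(=O)(=O)Oc2ccccc2CC)c1`, differs from compound 2 by one change: methyl in place of hydrogen on a saturated chain carbon bound to an aromatic carbon. Within the data shown here, no measured pair shows this single change on its own, so the expected step is small, in either direction or none beyond the scatter. The estimated step from compound 2 to compound 3 is a 1.3-fold lower number from compound 2 to compound 3 (0.13 log units; within the scatter). Compound 3 is expected to give about 38000 nM, within 15000 nM to 90000 nM.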

Compound 3, half-maximal inhibitory concentration: 30000 nM
The estimate for compound 3 lay 1.3-fold (0.10 log units) above the measured number; low and high end bracket the measured number.
By their numbers in this assay, from the lowest: compounds 1, 3 and 2 (each within the scatter of the next, the first and the last beyond it).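

Going from 2-methylphenyl to 2-ethylphenyl stays within the scatter (a 1.7-fold lower number from compound 2 to compound 3 (0.23 log units; within the scatter)), so at this position the added methyl makes no clear difference to the number. Compound 3 also stays within the scatter of compound 1 when hydrogen takes the place of chloromethyl on a saturated chain carbon, two bonds along the chain from an amide-type nitrogen (a 1.3-fold higher number from compound 1 to compound 3 (0.10 log units; within the scatter)). Nothing available accounts for either step. Going by these compounds, whether a longer chain such as propyl, or an amine, at this position would move the number beyond the scatter stays open.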